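Replacing the Oxadiazole Ring with a Pyridine Ring

A few compounds are considered here, and "the series" means these few. Any claim that something is new, unique, unknown or untested is made for them only; others in the source may bear on it.

Compound 3 `Cc1oc(C(=O)O)cc1COc1ccc(-c2nnco2)cc1` carries a 1,3,4-oxadiazol-2-yl group on an aromatic carbon of the shared core. In an assay on cells for displacement of a labelled ligand from prostaglandin E2 receptor EP4 subtype (Homo sapiens), read by scintillation counting (on this read-out higher numbers stand for weaker inhibition and lower numbers for stronger inhibition), compound 3 gives only a limit, > 10000 nM, and no number. Compound 3 thus sits at the limit of > 10000 nM in this assay, at which 1 of the 3 values shown sits. Its two neighbours carry six-membered aromatic rings at the same place: compound 1 `COc1ccccc1-c1ccc(OCc2cc(C(=O)O)oc2C)cc1`, with a 2-methoxyphenyl group, gives 1600 nM in this assay, and compound 2 `Cc1oc(C(=O)O)cc1COc1ccc(-c2ccc(C#N)cc2)cc1`, with a 4-cyanophenyl group, gives 1500 nM. The step of an at least 6.2-fold higher number from compound 1 to compound 3 (0.79 log units; beyond the scatter) and the step of an at least 6.6-fold higher number from compound 2 to compound 3 (0.82 log units; beyond the scatter) point the same way, so compound 3 stands as the weakest of the three, while the step of a 1.1-fold lower number from compound 1 to compound 2 (0.03 log units; within the scatter) is small. Compound 4 `Cc1oc(C(=O)O)cc1COc1ccc(-c2ccncc2)cc1` has not yet been measured in this assay. It differs from compound 3 in one place: pyridin-4-yl in place of 1,3,4-oxadiazol-2-yl on an aromatic carbon. Because the steps of an at least 6.2-fold higher number from compound 1 to compound 3 (0.79 log units; beyond the scatter) and an at least 6.6-fold higher number from compound 2 to compound 3 (0.82 log units; beyond the scatter) both rose when a six-membered aromatic ring gave way to the five-membered one, the reverse change is expected to lower the number, although the pyridin-4-yl ring is not the same as either phenyl group in compounds 1 and 2, so the size remains uncertain. Compound 4 is therefore expected to give about 3000 nM in this assay, within a range from 1000 nM to 10000 nM. The expected step is an at least 3.3-fold lower number from compound 3 to compound 4 (0.52 log units; beyond the scatter).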

Compound 4, inhibition constant: > 10000 nM
Compound 4: no number, only a limit; the forecaster's own chance of this, stated with the estimate: 30%; middle value at least 3.3-fold (0.52 log units) from the limit.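

In this assay, the pyridin-4-yl group is a six-membered aromatic ring like the groups it replaces, yet the change from 2-methoxyphenyl gives an at least 6.2-fold higher number from compound 1 to compound 4 (0.79 log units; beyond the scatter), and the change from 4-cyanophenyl gives an at least 6.6-fold higher number from compound 2 to compound 4 (0.82 log units; beyond the scatter). Among these compounds, then, a six-membered aromatic ring on this carbon is not enough to give a number, and only the two substituted phenyl groups do so. Compound 4 gives only a limit, as does compound 3, so no step that joins these two can be read, and the set now divides into compounds with numbers and compounds with limits: the limit of > 10000 nM in this assay, at which 2 of the 4 values shown sit.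

The compounds shown leave open whether the ring nitrogen or the lack of a substituent sets compound 4 apart, as compounds 1 and 2 both carry a substituent on a ring of carbon only, while the ring of compound 4 carries none. Going by these compounds, an unsubstituted phenyl group, or a pyridin-4-yl ring bearing a methoxy group or a nitrile, would separate these two changes, and how far compounds 3 and 4 lie past their limits also remains unknown.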